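Swapping Bromophenyl for Pyridyl on Two Different Cores

The compounds below may be only part of what the source reports. "The series", "measured", "known", "first", "only" and "open" are said of these compounds alone.

Compound 1 `C=C1C(=O)[C@]23C[C@@]1(O)CC[C@H]2c1ccc(OS(=O)(=O)c2ccc(C)cc2)c(C)c1[C@@H]3Cn1cc(-c2ccccn2)nn1` and compound 2 `C=C1C(=O)[C@]23C[C@@]1(O)CC[C@H]2c1ccc(OS(=O)(=O)c2ccc(C)cc2)c(C)c1[C@@H]3Cn1cc(-c2ccc(Br)cc2)nn1` share one core and differ only in the group carried on the triazole ring. Compound 3 `C=C1C[C@]23C[C@@]1(O)CC[C@@H]2c1cccc(C)c1[C@@H]3Cn1cc(-c2ccc(Br)cc2)nn1` and compound 4 `C=C1C[C@]23C[C@@]1(O)CC[C@@H]2c1cccc(C)c1[C@@H]3Cn1cc(-c2ccccn2)nn1` share a second core; the difference between the two cores is not broken down here. In a functional assay on HL-60 cells (Homo sapiens) for cytotoxicity, read by MTT assay, with a stated time of 4 days (on this read-out lower numbers stand for stronger inhibition and higher numbers for weaker inhibition), compound 2 gives 1020 nM. In this assay compound 1 gives 1810 nM. The change between them, (pyridin-2-yl in place of 4-bromophenyl on an aromatic carbon), made a step of a 1.8-fold higher number from compound 2 to compound 1 (0.25 log units; within the scatter).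

Compound 3 reaches only the limit of > 20000 nM in this assay, which is a limit of the assay rather than a number. The same change is now made on the core of compound 3: pyridin-2-yl in place of 4-bromophenyl on an aromatic carbon. The two descriptions of the place are the same word for word, so this is the same change, only on a different core.

Since the measured pair moved within the scatter, the step from compound 3 to compound 4 is expected to be a step that the limit leaves unreadable from compound 3 to compound 4. This expectation rests on compound 3 and on (the limit of > 20000 nM in this assay, at which 1 of the 3 values shown sits), which leaves the starting point itself unknown beyond that limit. Compound 4 is therefore estimated at 35000 nM in this assay. For compound 4 the expected range runs from 12000 nM to 120000 nM, and it is likely that the assay again returns only a limit.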

Compound 4, half-maximal inhibitory concentration: > 20000 nM
Compound 4 gave a limit, no number (the forecaster's own chance of this, stated with the estimate: 80%); the middle value is on the limit's open side.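

In this assay compound 4 gives > 20000 nM which is a limit of the assay and not a number. Among these compounds, no step from compound 3 to compound 4 can be read, because both compounds stand at a limit: the limit of > 20000 nM in this assay, at which 2 of the 4 values shown sit. The compounds shown leave open whether pyridin-2-yl in place of 4-bromophenyl changes the value at all on the core of compound 3.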